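The compounds below may be only part of what the source reports. "The series", "measured", "known", "first", "only" and "open" are said of these compounds alone.

The account begins with three pyridopyrazinone-free descriptions kept simple: compound 1 `CC(C)(C)c1cc(NC(=O)Nc2cccc(Oc3ccnc4[nH]c(=O)cnc34)c2)n(-c2ccccc2)n1` gives 1.4 h in an in vivo ADME assay on the whole organism (strain C57BL/cAnNCrl) for metabolic stability, with Mus musculus as the target, at a dose of 10 mg/kg by the oral route (on this read-out lower numbers stand for a shorter-lived compound and higher numbers for a longer-lived compound), compound 2 `CSc1cc(Oc2ccnc3[nH]c(=O)cnc23)ccc1NC(=O)Nc1cc(C(C)(C)C)nn1-c1ccc(C)cc1` gives 7.9 h in this assay, and compound 3 `Cc1ccc(-n2nc(C(C)(C)C)cc2NC(=O)Nc2ccc(Oc3ccnc4[nH]c(S)nc34)cc2F)cc1` gives 3.3 h in this assay. Compound 2 stands highest of the three; compound 3 lies nearest and compound 1 furthest, both gaps beyond the usual scatter. Compound 4 `Cc1ccc(-n2nc(C(C)(C)C)cc2NC(=O)Nc2ccc(Oc3ccnc4[nH]c(=O)cnc34)cc2)cc1` differs from compound 2 in one place: hydrogen in place of methylsulfanyl on an aromatic carbon. Among the compounds with values here, no measured pair isolates that change, so the expected step is moderate and downward, because compound 1 1.4 h and compound 3 3.3 h both lack methylsulfanyl and lie lower. The estimated step is a 2.0-fold lower number from compound 2 to compound 4 (0.30 log units; within the scatter) in this assay. Compound 4 is expected to give 4 h, with a range from 2 h to 8 h.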

Compound 4, half-life: 6.3 h
Beside the measured number, compound 4's estimate is 1.6-fold (0.20 log units) below it; measured number inside the range.
By their numbers in this assay, from the lowest: compound 1; then compounds 3, 4 and 2 (each within the scatter of the next, the first and the last beyond it).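

Within the data shown here, replacing methylsulfanyl with hydrogen on this aromatic carbon gives the first direct reading of this position: a 1.3-fold lower number from compound 2 to compound 4 (0.10 log units; within the scatter) in this assay. On this one pair, the two substituents cannot be told apart, so the half-life of compound 2 does not depend on methylsulfanyl being present. No measurement on hand explains this result. As far as these compounds go, whether an amine, a methoxy group or a carboxylic acid on the same carbon would change the half-life remains open. So does whether this swap would read the same way in a compound that differs elsewhere.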